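A few compounds are considered here, and "the series" means these few. Any claim that something is new, unique, unknown or untested is made for them only; others in the source may bear on it.

Working notes on the series.

Compound 1 `COc1ccc2nc(-c3ccc(N/C=C\C(=O)c4cc(OC)c(OC)c(OC)c4)c(C)c3)sc2c1` and compound 3 `COc1cc(OC)c2sc(-c3ccc(N/C=C\C(=O)c4cc(OC)c(OC)c(OC)c4)c(C)c3)nc2c1` differ in their cores; the difference between the two cores is not broken down here. In a functional assay on HeLa cells (Homo sapiens) for antiproliferative activity, read by sulforhodamine B assay, with a stated time of 48 h (on this read-out lower numbers stand for stronger inhibition and higher numbers for weaker inhibition), compound 1 gives 16100 nM, and in this assay compound 3 gives 16400 nM; the two numbers sit within the scatter of each other.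

Compound 2 `COc1cc(OC)c2sc(-c3ccc(N/C=C\C(=O)c4cc(OC)c(OC)c(OC)c4Br)c(C)c3)nc2c1` is compound 3 with one change, (bromo in place of hydrogen on an aromatic carbon). In this assay compound 2 gives 14700 nM, so the step is a 1.1-fold lower number from compound 3 to compound 2 (0.05 log units; within the scatter).

Compound 4 `COc1ccc2nc(-c3ccc(N/C=C\C(=O)c4cc(OC)c(OC)c(OC)c4Br)c(C)c3)sc2c1` is compound 1 with the change (bromo in place of hydrogen on an aromatic carbon). Going by the values given here, the two descriptions of the surroundings of the change are identical word for word, so this is the same change as the one from compound 3 to compound 2, made on the core of compound 1 instead.

Among the compounds with values here, for compound 4 the expected step in this assay is a 1.1-fold lower number from compound 1 to compound 4 (0.03 log units; within the scatter), resting on the single earlier step of a 1.1-fold lower number from compound 3 to compound 2 (0.05 log units; within the scatter), which stayed within the scatter. On that basis compound 4 is estimated at 15000 nM, with a range from 8500 nM to 26000 nM.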

Compound 4, half-maximal inhibitory concentration: 13400 nM
Estimate against measurement, compound 4: 1.1-fold (0.05 log units) above, within the range that was stated.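

Bromo in place of hydrogen on an aromatic carbon gives, in this assay, a 1.2-fold lower number from compound 1 to compound 4 (0.08 log units; within the scatter), and the step reads alike on the two cores: the same change on two cores in this assay, a 1.1-fold lower number (0.05 log units; within the scatter) from compound 3 to compound 2 and a 1.2-fold lower number (0.08 log units; within the scatter) from compound 1 to compound 4, 1.1-fold (0.03 log units) apart, within the scatter of two such steps

On these two cores, then, the change carries over without a detectable difference. Going by these compounds alone, what carries over, however, is a step that stays within the scatter on each core, so the agreement does not show that bromo shifts the number on either core, only that neither core reveals a shift. Two cores also give no basis for predicting the step on a third core, or for a change that does produce a step beyond the scatter.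

Bromo is the only group shown at this place, so it remains open whether fluoro, chloro, a hydroxyl or an amine there would move the number beyond the scatter on either core. On these data alone, it also remains open whether such a step would hold from one core to the other.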